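Swapping a Heteroaryl for an Acetyl on the Shared Core

A few compounds are considered here, and "the series" means these few. Any claim that something is new, unique, unknown or untested is made for them only; others in the source may bear on it.

Compound 1 `CC(C)CCn1nc(-c2cccs2)c(O)c(C2=NS(=O)(=O)c3cc(NC(=O)C4CC4)ccc3N2)c1=O` gives 0.0833 h in an in vitro ADME assay on microsomes from liver (Homo sapiens) for metabolic stability, tested at 5 uM; on this read-out higher numbers stand for a longer-lived compound and lower numbers for a shorter-lived compound.
Compound 2 `CC(C)CCn1nc(-c2cccs2)c(O)c(C2=NS(=O)(=O)c3cc(-c4cnoc4)ccc3N2)c1=O` gives 0.5 h in this assay.

Only these two numbers are known. Compound 2 stands at the higher of the two, and its nearest neighbour is compound 1, separated by a 6.0-fold higher number from compound 1 to compound 2 (0.78 log units; beyond the scatter), a gap beyond the usual scatter of repeated measurements.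

Compound 3 `CC(=O)c1ccc2c(c1)S(=O)(=O)N=C(c1c(O)c(-c3cccs3)nn(CCC(C)C)c1=O)N2` has not yet been measured. It differs from compound 2 in one place: acetyl in place of 1,2-oxazol-4-yl on an aromatic carbon. Within the data shown here, the only measured step concerns this same place, where a (cyclopropylcarbonyl)amino group was exchanged for 1,2-oxazol-4-yl, giving a 6.0-fold higher number from compound 1 to compound 2 (0.78 log units; beyond the scatter). Among the measured compounds shown here, that step shows that an exchange at this place can shift the half-life by a modest but real amount, yet neither of the two groups seen so far is acetyl, so it offers no direct precedent for the new group. With no closer comparison available, the expected step of a 1.7-fold lower number from compound 2 to compound 3 (0.22 log units; within the scatter) is kept small, leaning slightly downward and possibly within the scatter. The half-life of compound 3 in this assay is therefore estimated at 0.3 h, with a range from 0.1 h to 0.9 h.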

Compound 3, half-life: 0.0717 h
For compound 3 the middle estimate is 4.2-fold (0.62 log units) above the measured one; measured number below the stated range.
By their numbers in this assay, from the lowest: compounds 3 and 1 (each within the scatter of the next); then compound 2.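

The 1,2-oxazol-4-yl group now stands out at this position. Replacing it with a much different group gives a 7.0-fold lower number from compound 2 to compound 3 (0.84 log units; beyond the scatter), so the longer half-life seen earlier was not simply a feature of moving away from the (cyclopropylcarbonyl)amino group. Acetyl and (cyclopropylcarbonyl)amino, the two groups here that contain a carbonyl, cannot be told apart in this assay, with a 1.2-fold lower number from compound 1 to compound 3 (0.07 log units; within the scatter), even though one is attached through carbon and the other through nitrogen. No measurement is available that explains why the half-life shifts with these exchanges, and three compounds are too few to tie it to the carbonyl, the five-membered ring or anything else.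

Going by these compounds, it remains open whether the longer half-life belongs to 1,2-oxazol-4-yl in particular or would also appear with other aromatic rings at this place, such as a phenyl, pyridine or pyrazole ring. It is equally unclear how groups with no carbonyl and no ring, such as a methyl, a methoxy or an amine, would compare with the three groups shown.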